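A few compounds are considered here, and "the series" means these few. Any claim that something is new, unique, unknown or untested is made for them only; others in the source may bear on it.

Compound 1 `CCOc1ccc(/C=C/C(=O)Nc2nc(-c3c(C)cc(C)cc3C)cs2)cc1`: 2480 nM in a functional assay on K562 cells (Homo sapiens) for inhibition, read by MTT assay, with a stated time of 96 h; on this read-out lower numbers stand for stronger inhibition and higher numbers for weaker inhibition
Compound 2 `Cc1cc(C)c(-c2csc(NC(=O)/C=C/c3ccc([N+](=O)[O-])cc3)n2)c(C)c1`: 32200 nM

Among the two compounds measured in this assay, compound 1 gives the lowest number, with compound 2 its nearest neighbour. Compound 3 `Cc1cc(C)c(-c2csc(NC(=O)/C=C/c3ccncc3)n2)c(C)c1` has not been measured yet. It differs from compound 1 in one place: pyridin-4-yl in place of 4-ethoxyphenyl on a double-bonded chain carbon bound to a double-bonded chain carbon. Among the compounds with values here, the one measured step that bears on this is the replacement on the same aromatic ring in a 13-fold higher number from compound 1 to compound 2 (1.11 log units; beyond the scatter), a large upward step. That step swaps out the same ethoxy group that compound 3 also loses, though what enters is different, so it only partly describes the present change. On that basis a step upward beyond the scatter is expected, smaller than the measured one, namely a 3.6-fold higher number from compound 1 to compound 3 (0.56 log units; beyond the scatter). Compound 3 is therefore estimated at 9000 nM, with a range from 2500 nM to 40000 nM.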

Compound 3, half-maximal inhibitory concentration: 9390 nM
Estimate against measurement, compound 3: 1.0-fold (0.02 log units) below; the measured number falls inside the stated range.
By their numbers in this assay, from the lowest: compound 1; then compound 3; then compound 2.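

Until now only the group on the aromatic ring had changed, whereas here the ring itself changes, from carbon only to one holding a nitrogen, and the group entering is smaller by the heavy-atom count. Pyridin-4-yl in place of 4-ethoxyphenyl gives a 3.8-fold higher number from compound 1 to compound 3 (0.58 log units; beyond the scatter) on this chain carbon, so 4-ethoxyphenyl remains the best of the three groups on this read-out, where a lower number means stronger inhibition. Pyridin-4-yl in place of 4-nitrophenyl gives a 3.4-fold lower number from compound 2 to compound 3 (0.54 log units; beyond the scatter) here, which shows that losing 4-ethoxyphenyl need not cost as much as the nitro compound suggested.

As far as these compounds go, whether plain phenyl, 4-methoxyphenyl or 4-aminophenyl would stand nearer to compound 1 remains open, as does whether pyridin-3-yl would match pyridin-4-yl. Nothing measured here gives a reason for this order.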